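The source may hold more compounds than are shown below. What is called first, only, known or untested is meant among the compounds shown, and "the series" means these compounds.

Series notes. Compound 1 `O=c1ccn(CCCCCOc2ccccc2)c(=O)[nH]1` carries a hydrogen at the aromatic carbon in question; compound 2 `Cc1cccc(OCCCCCn2ccc(=O)[nH]c2=O)c1` carries a methyl there. In an ADME assay on HEL cells (Homo sapiens) for cytotoxicity (on this read-out lower numbers stand for higher toxicity in this test and higher numbers for lower toxicity in this test), compound 1 gives only a limit, > 100000 nM. In this assay compound 2 likewise gives only a limit, > 100000 nM. The step that the two limits leave unreadable from compound 1 to compound 2 therefore cannot be read, since both ends sit at the limit of > 100000 nM in this assay, at which 2 of the 2 values shown sit. On the numbers shown, compound 2 stands at a limit in this assay, with nothing in the series that separates it from compound 1.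

Compound 3 `Cc1cc(C)cc(OCCCCCn2ccc(=O)[nH]c2=O)c1` differs from compound 2 by methyl in place of hydrogen on an aromatic carbon. Among the compounds with values here, the only measured step that bears on this change is the one from compound 1 to compound 2, which introduced the first methyl on the same ring and left no readable size. A second methyl of the same kind gives no ground to expect a move beyond the scatter in this assay, so the expected step that the limit leaves unreadable from compound 2 to compound 3 is set near zero. Compound 3 is expected at 150000 nM, in the range 50000 nM to 500000 nM, and most likely reported again only as a limit in this assay.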

Compound 3, half-maximal cytotoxic concentration: > 100000 nM
Compound 3 gave a limit, no number; the forecaster's own chance of this, stated with the estimate: 85%; the middle value does not contradict the limit.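

In this assay, within the data shown here, compound 3 gives > 100000 nM as a limit and not a number, so no step from compound 2 to compound 3 can be read. The series stands as follows: (the limit of > 100000 nM in this assay, at which 3 of the 3 values shown sit). Whether methyl in place of hydrogen on an aromatic carbon changes the read-out at all stays open: in this assay none of the compounds shown gives a number.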